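A few compounds are considered here, and "the series" means these few. Any claim that something is new, unique, unknown or untested is made for them only; others in the source may bear on it.

Working notes on the series. In a functional assay on Ehrlich cells (Mus musculus) for cytotoxicity, read by LDH release, with a stated time of 48 h (on this read-out lower numbers stand for stronger inhibition and higher numbers for weaker inhibition), compound 1 `Cc1ccc(OCC(=O)NNC(=O)c2cc3ccccc3oc2=O)c(C(=O)c2ccc(Cl)cc2)c1` gives 58000 nM and compound 2 `Cc1ccc(OCC(=O)NNC(=O)c2cc3ccccc3oc2=O)c(C(=O)c2ccc(Br)cc2)c1` gives 89000 nM. Within the data shown here, these two numbers lie within the scatter of each other, so compound 2 cannot be ranked against the only other measured compound. The next compound is compound 3 `Cc1ccc(C(=O)c2cc(C)ccc2OCC(=O)NNC(=O)c2cc3ccccc3oc2=O)cc1`, with methyl in place of bromo on an aromatic carbon, para to a large group, which turns 4-bromophenyl into 4-methylphenyl: methyl in place of bromo on an aromatic carbon. Among the measured compounds shown here, one measured step bears on this change, a swap of bromo in place of chloro on the same aromatic carbon. For the measured compounds named here, with a 1.5-fold higher number from compound 1 to compound 2 (0.19 log units; within the scatter) as the only evidence at this place, no step beyond the scatter is expected in this assay, and no direction is favoured. Going by the values given here, no measured compound carries methyl here, so this expectation rests on thin data. The expected step is a 1.3-fold lower number from compound 2 to compound 3 (0.10 log units; within the scatter). For compound 3 the estimated value is 70000 nM, with an expected range of 33000 nM to 150000 nM.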

Compound 3, half-maximal inhibitory concentration: 81400 nM
For compound 3 the middle estimate is 1.2-fold (0.07 log units) below the measured one; low and high end bracket the measured number.
By their numbers in this assay, from the lowest: compounds 1, 3 and 2 (each within the scatter of the next).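

In this assay methyl now stands with chloro and bromo on the aromatic carbon para to a large group, and replacing bromo gives a 1.1-fold lower number from compound 2 to compound 3 (0.04 log units; within the scatter) while replacing chloro gives a 1.4-fold higher number from compound 1 to compound 3 (0.15 log units; within the scatter) in the same series. The earlier compounds shown here compared only two halogens at this place, whereas compound 3 extends the comparison to a group with a carbon as its single heavy atom, and 4-methylphenyl reads the same as 4-bromophenyl within the scatter, so compounds 1, 2 and 3 cannot be ranked against each other. No supporting measurement bears on why the three substituents read alike here.

From the compounds shown here alone, this flat reading therefore holds only for these three groups of a single heavy atom, and it remains open whether an amine, a carboxylic acid or a longer alkyl chain on this carbon would give a step beyond the scatter. The compounds shown also differ in this one place only, so they say nothing about how changes elsewhere in the core of compound 1 would read.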